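Trimethoxyphenyl in place of cyanophenyl on the ether carbon

A few compounds are considered here, and "the series" means these few. Any claim that something is new, unique, unknown or untested is made for them only; others in the source may bear on it.

The series shares one core: compound 1 `FC(F)(F)c1ccc(CN2CCN(Cc3cc(-c4ccc(OCc5cccc(Cl)c5)cc4)on3)CC2)cc1` and compound 2 `N#Cc1ccc(COc2ccc(-c3cc(CN4CCN(Cc5ccc(C(F)(F)F)cc5)CC4)no3)cc2)cc1` differ only in the group on the saturated chain carbon bound to an oxygen on an aromatic ring. In a functional assay on Mahlavu cells (Homo sapiens) for antiproliferative activity, read by sulforhodamine B assay, with a stated time of 72 h (on this read-out higher numbers stand for weaker inhibition and lower numbers for stronger inhibition), compound 1 gives 4100 nM, and compound 2 gives 4300 nM. The step of a 1.0-fold higher number from compound 1 to compound 2 (0.02 log units; within the scatter) shows that exchanging these two groups left the read-out unchanged, and compound 2 and compound 1 sit within the scatter of each other. Compound 3 `COc1cc(COc2ccc(-c3cc(CN4CCN(Cc5ccc(C(F)(F)F)cc5)CC4)no3)cc2)cc(OC)c1OC` carries a further change at the same place: 3,4,5-trimethoxyphenyl in place of 4-cyanophenyl on a saturated chain carbon bound to an oxygen on an aromatic ring. Among the compounds with values here, only the step from compound 1 to compound 2 bears on this position, and it was flat; no measured step tests the entering group itself. The expected step of a 1.1-fold lower number from compound 2 to compound 3 (0.03 log units; within the scatter) is therefore none beyond the scatter. Compound 3 is estimated at 4000 nM, within a range of 1500 nM to 12000 nM.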

Compound 3, half-maximal inhibitory concentration: 5800 nM
The estimate for compound 3 lay 1.5-fold (0.16 log units) below the measured number; low and high end bracket the measured number.
By their numbers in this assay, from the lowest: compounds 1, 2 and 3 (each within the scatter of the next).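

With the 3,4,5-trimethoxyphenyl group on the saturated chain carbon bound to an oxygen on an aromatic ring, this assay gives a 1.3-fold higher number from compound 2 to compound 3 (0.13 log units; within the scatter) and a 1.4-fold higher number from compound 1 to compound 3 (0.15 log units; within the scatter) as its two new steps, and neither leaves the scatter. The position, flat so far for one exchange between a 3-chlorophenyl and a 4-cyanophenyl group, thus stays flat when a group of 8 heavy atoms with 1 hydrogen-bond acceptor gives way to one of 12 heavy atoms with 3, and all three compounds lie within the scatter of one another. Nothing available explains why the read-out stays flat here.

Going by these compounds, all three groups at this place contain a six-membered aromatic ring, so it remains open whether a group without one, such as a carboxylic acid or a short chain ending in an amine, would shift the number in this assay at all. On these data alone, whether changes elsewhere on the shared core would do so is equally open.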